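The compounds below may be only part of what the source reports. "The series", "measured", "known", "first", "only" and "open" are said of these compounds alone.

Three measured compounds share one core. Compound 1 `c1cncc(N2CC[C@@H]3CN[C@@H]3C2)c1` gives 330 nM in a functional assay on HEK293 cells for agonist activity at Neuronal acetylcholine receptor; alpha4/beta2 (Homo sapiens), read by FLIPR; on this read-out higher numbers stand for an effect only at larger amounts of compound and lower numbers for an effect already at smaller amounts. Compound 2 `Brc1cncc(N2CC[C@@H]3CN[C@@H]3C2)c1` gives 1000 nM, and compound 3 `COc1cncc(N2CC[C@@H]3CN[C@@H]3C2)c1` gives 2700 nM, the highest of the three numbers, lying a 2.7-fold higher number from compound 2 to compound 3 (0.43 log units; beyond the scatter) and an 8.2-fold higher number from compound 1 to compound 3 (0.91 log units; beyond the scatter). Compound 4 `CCOc1cncc(N2CC[C@@H]3CN[C@@H]3C2)c1` differs from compound 3 by methyl in place of hydrogen on a saturated chain carbon bound to an oxygen on an aromatic ring. Among the measured compounds shown here, no measured step tests this lengthening itself; the steps of a 3.0-fold higher number from compound 1 to compound 2 (0.48 log units; beyond the scatter) and an 8.2-fold higher number from compound 1 to compound 3 (0.91 log units; beyond the scatter) only show that each group placed on that aromatic carbon raised the number, and the larger group raised it more. In this assay compound 4 is therefore expected to show a step of a 1.7-fold higher number from compound 3 to compound 4 (0.22 log units; within the scatter), toward a somewhat higher number. The estimate for compound 4 is 4500 nM, within a range from 1500 nM to 14000 nM.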

Compound 4, half-maximal effective concentration: 1350 nM
Compound 4: middle estimate off by 3.3-fold (0.52 log units), on the high side; the measured number lies below the stated range.
By their numbers in this assay, from the lowest: compound 1; then compounds 2, 4 and 3 (each within the scatter of the next, the first and the last beyond it).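

Lengthening methoxy to ethoxy does not carry the number further up as the earlier steps suggested: with a 2.0-fold lower number from compound 3 to compound 4 (0.30 log units; within the scatter) in this assay the two groups cannot be told apart, and compound 4 goes against the idea that a larger group here raises the number more. Ethoxy and bromo also cannot be told apart, with a 1.4-fold higher number from compound 2 to compound 4 (0.13 log units; within the scatter) inside the scatter, whereas a 4.1-fold higher number from compound 1 to compound 4 (0.61 log units; beyond the scatter) shows that ethoxy in place of hydrogen still lies beyond it. No measurement at hand explains this result. From the compounds shown here alone, whether a longer chain or an amine on this aromatic carbon would stay at this level remains open.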